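This account rests on a few compounds, and the source may have more. Where it says the series, first, only, none or still open, it means among the compounds named here.

Compound 1, `CCn1cc2ccc(N/C(C)=C3\C(=O)C=C(C)OC3=O)cc2n1`: in an ADME assay on RAW264.7 cells (Mus musculus) for cytotoxicity, read by resazurin assay, with a stated time of 48 h (on this read-out higher numbers stand for lower toxicity in this test and lower numbers for higher toxicity in this test), a limit, not a number: > 100000 nM
Compound 2, `C=CCn1cc2ccc(N/C(C)=C3\C(=O)C=C(C)OC3=O)cc2n1`: in this assay a limit, not a number: > 100000 nM
Compound 3, `CCn1ncc2cc(N/C(C)=C3\C(=O)C=C(C)OC3=O)ccc21`: in this assay a limit, not a number: > 100000 nM

All three measured values sit at the limit of > 100000 nM in this assay, at which 3 of the 3 values shown sit; none is a read number. The change from compound 1 to compound 2 is vinyl in place of methyl on a saturated chain carbon bound to an aromatic nitrogen. The step that the two limits leave unreadable from compound 1 to compound 2 is unreadable because both ends rest at the limit of > 100000 nM in this assay, at which 3 of the 3 values shown sit. Compound 3 shares its atoms with compound 1 but joins them differently; the difference between the two cores is not broken down here.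

Compound 4, `C=CCn1ncc2cc(N/C(C)=C3\C(=O)C=C(C)OC3=O)ccc21`, is not yet measured in this assay. It differs from compound 3 by vinyl in place of methyl on a saturated chain carbon bound to an aromatic nitrogen, the same change as that from compound 1 to compound 2, at the same kind of place.

The expected step that the limit leaves unreadable from compound 3 to compound 4 is essentially none, since the same change left compound 1 and compound 2 both at the limit of > 100000 nM in this assay, at which 3 of the 3 values shown sit. Compound 4 is therefore expected at 150000 nM, between 80000 nM and 400000 nM, and most likely reported again only as a limit.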

Compound 4, half-maximal cytotoxic concentration: > 100000 nM
Compound 4 was reported as a limit; the forecaster's own chance of this, stated with the estimate: 85%; the middle value does not contradict the limit.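

No new step can be read from compound 3 to compound 4 in this assay, because both ends are limits, not numbers: the limit of > 100000 nM in this assay, at which 4 of the 4 values shown sit.

The compounds shown leave open where any of the four reaches its half-maximal cytotoxic concentration, and whether ethyl to allyl or the difference between the two cores changes that concentration at all.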